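Ring size of the cycloalkylmethyl group at the amine nitrogen

A few compounds are considered here, and "the series" means these few. Any claim that something is new, unique, unknown or untested is made for them only; others in the source may bear on it.

Compound 1 `COc1cc(N)c(Cl)cc1NC(=O)C1CCN(CC2CC2)CC1`, compound 2 `COc1cc(N)c(Cl)cc1NC(=O)C1CCN(C/C=C/c2ccccc2)CC1` and compound 3 `COc1cc(N)c(Cl)cc1NC(=O)C1CCN(CC2CCC2)CC1` share one core and differ only in the group on a saturated chain carbon bound to an amine nitrogen in a ring. In a functional assay on the whole organism for antagonist activity, with Mus musculus as the target (a higher number here means that more compound is needed for the effect, a lower number that less compound is needed), compound 1 gives only a limit, > 10 mg/kg. Compound 2 likewise gives a limit, > 10 mg/kg. Compound 3 too gives a limit, > 10 mg/kg. Hence a step that the two limits leave unreadable from compound 1 to compound 2, a step that the two limits leave unreadable from compound 1 to compound 3 and a step that the two limits leave unreadable from compound 2 to compound 3 remain unreadable, the reason being (the limit of > 10 mg/kg in this assay, at which 3 of the 3 values shown sit). Compound 4 `COc1cc(N)c(Cl)cc1NC(=O)C1CCN(CC2CCCC2)CC1` carries cyclopentyl in place of cyclobutyl on a saturated chain carbon bound to an amine nitrogen in a ring. Every measured step bears on this change, yet none yields a size. Compound 4 is therefore expected to sit at the same limit, with a step that the limit leaves unreadable from compound 3 to compound 4 expected to be small. The estimate for compound 4 is 20 mg/kg, ranging from 6 mg/kg to 60 mg/kg.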

Compound 4, dose for half-maximal effect: > 10 mg/kg
Compound 4: no number, only a limit; the forecaster's own chance of this, stated with the estimate: 80%; the middle value does not contradict the limit.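

Going by these compounds alone, compound 4 gives only a limit, so no new step from compound 1, compound 2 or compound 3 to compound 4 can be read in this assay: the limit of > 10 mg/kg in this assay, at which 4 of the 4 values shown sit. Whether ring size at this place changes the dose stays open: none of the compounds shown gives a number.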